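This account rests on a few compounds, and the source may have more. Where it says the series, first, only, none or still open, it means among the compounds named here.

Measured so far:
Compound 1 `O=C(/C=C/c1ccc(N2CCCCC2)cc1)c1ccc(Br)s1`: in an ADME assay on PBMC cells (Homo sapiens) for cytotoxicity, with a stated time of 5 days (a lower number here means a stronger inhibitor, a higher number a weaker inhibitor), compound 1 reaches only a limit, > 100000 nM.
Compound 2 `c1csc(C2=NNC(c3ccc(N4CCCCC4)cc3)C2)c1`: in this assay compound 2 gives 20800 nM.

Within the data shown here, compound 2 holds the only number in the set. For compound 1 the entry is a limit, (the limit of > 100000 nM in this assay, at which 1 of the 2 values shown sits). Compound 3 `Cc1cc(C2=NNC(c3ccc(N4CCCCC4)cc3)C2)c(C)s1` differs from compound 2 by 2,5-dimethylthiophen-3-yl in place of thiophen-2-yl on a carbon with a double bond to nitrogen. Among the measured compounds shown here, no measured step supports a direction, so in this assay no move beyond the scatter is expected. Compound 3 is estimated at 20000 nM (range 6000 nM to 70000 nM), the expected step being a 1.0-fold lower number from compound 2 to compound 3 (0.02 log units; within the scatter).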

Compound 3, half-maximal inhibitory concentration: 77500 nM
Compound 3: middle estimate off by 3.9-fold (0.59 log units), on the low side, outside the stated range (above it).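

In this assay, the group on this carbon with a double bond to nitrogen can move the read-out: 2,5-dimethylthiophen-3-yl in place of thiophen-2-yl gives a 3.7-fold higher number from compound 2 to compound 3 (0.57 log units; beyond the scatter). Among these compounds, this is the first readable step, and it runs towards a weaker inhibitor. Compound 1 remains a limit, not a number: the limit of > 100000 nM in this assay, at which 1 of the 3 values shown sits.

The compounds shown leave open whether the two methyl groups or the change from thiophen-2-yl to thiophen-3-yl carries this step. From the compounds shown here alone, how a phenyl or pyridine ring would read at this carbon also remains open.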